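Swapping Fluoro for Nitro on an Aromatic Carbon

The source may hold more compounds than are shown below. What is called first, only, known or untested is meant among the compounds shown, and "the series" means these compounds.

Measured compounds:
- Compound 1 `COc1ccc(OCC2=NCCO2)cc1`, which in a toxicity assay on the whole organism with Rattus norvegicus as the target, at a dose of 400 mg/kg by the oral route (a lower number here means a weaker effect, a higher number a stronger effect of the compound at the dose given), gives 90%
- Compound 2 `Clc1ccc(OCC2=NCCO2)cc1`, which in this assay gives 90%
- Compound 3 `Fc1ccc(OCC2=NCCO2)cc1`, which in this assay gives 50%

Compound 3 stands lowest of the three numbers: the step of a number 40 percentage points lower from compound 1 to compound 3 (beyond the scatter) and the step of a number 40 percentage points lower from compound 2 to compound 3 (beyond the scatter) both go beyond the scatter, whereas the step of no change at the digits printed from compound 1 to compound 2 (within the scatter) stays within it. So methoxy and chloro on that aromatic carbon behave alike, and fluoro alone gives the weaker effect.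

Compound 4 `O=[N+]([O-])c1ccc(OCC2=NCCO2)cc1` carries a further change at the same place: nitro in place of fluoro on an aromatic carbon.

Among the measured compounds shown here, no measured step involves nitro, so the expectation rests on the two steps away from fluoro. Both were large and both pointed the same way, toward the higher numbers of compound 1 and compound 2. Nitro, like methoxy and chloro, is a larger group than fluoro, so a step upward in this assay is expected, of about a number 30 percentage points higher from compound 3 to compound 4 (beyond the scatter).

Compound 4 is therefore estimated at 80%, with a range from 50% to 100%.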

Compound 4, a percentage reported as activity, at one dose (the size of the read-out at that dose, not a potency): 100%
Compound 4: the middle estimate sits 20 percentage points below what was measured, within the range that was stated.
By their numbers in this assay, from the lowest: compound 3; then compounds 1, 2 and 4 (each within the scatter of the next).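

Nitro joins methoxy and chloro at this place on the ring in this assay: a number 10 percentage points higher from compound 2 to compound 4 (within the scatter) and a number 10 percentage points higher from compound 1 to compound 4 (within the scatter), whereas a number 50 percentage points higher from compound 3 to compound 4 (beyond the scatter). Three different groups therefore give numbers within the scatter of one another, and compound 3, with fluoro, is the only one that stands apart, now with the lowest number against all three others. Nothing shown explains why fluoro differs from the other groups at this place.

The compounds shown leave open whether an amine, a carboxylic acid or a longer chain such as butoxy would stay with the high numbers or fall towards compound 3. They also leave open how plain hydrogen at this place would compare, which would show whether fluoro or the other three groups depart from the unsubstituted ring.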